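The compounds below may be only part of what the source reports. "The series", "measured", "known", "first", "only" and "open" are said of these compounds alone.

Measured so far:
compound 1 `CC(C)(C)C(=O)N1Cc2c(NC(=O)c3ccncc3)n[nH]c2C1(C)C` — 205000 nM
compound 2 `CN1CCC(C(=O)N2Cc3c(NC(=O)Nc4cccc(F)c4)n[nH]c3C2(C)C)CC1` — > 225000 nM

In a physicochemical assay for solubility, at pH 7 (on this read-out higher numbers stand for higher solubility and lower numbers for lower solubility), compound 1 gives 205000 nM. For compound 2 this assay reports only a limit, > 225000 nM, so no number stands for compound 2 in this assay. Where compound 2 sits is given by the limit of > 225000 nM in this assay, at which 1 of the 2 values shown sits. Compound 3 `CN1CCC(C(=O)N2Cc3c(NC(=O)c4cccc(F)c4)n[nH]c3C2(C)C)CC1` is not yet measured in this assay. The change from compound 2 to compound 3 is 3-fluorophenyl in place of (3-fluorophenyl)amino on a carbonyl carbon. Within the data shown here, no step between two measured compounds is available here to calibrate a change of this kind, so the expectation rests on the two values shown. The step expected in this assay an at least 1.5-fold lower number from compound 2 to compound 3 (0.17 log units; that floor lies within the scatter) is a modest fall at most, quite possibly within the scatter, given that compound 1 gives 205000 nM in this assay with a non-urea carbonyl link and still reads high. Compound 3 is estimated at 150000 nM, with an expected range from 60000 nM to 225000 nM.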

Compound 3, solubility: > 225000 nM
Compound 3 was reported as a limit; the forecaster's own chance of this, stated with the estimate: 35%; middle value at least 1.5-fold (0.17 log units) away from the limit.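

In this assay compound 2 and compound 3 both stand only as limits, so no step can be read between them. Still open, as far as these compounds go, is how far 3-fluorophenyl in place of (3-fluorophenyl)amino on a carbonyl carbon shifts the read-out in this assay for this pair.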